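The compounds below may be only part of what the source reports. "The series", "measured", "known", "first", "only" and "open" are said of these compounds alone.

Compound 3 `O=C(C1CCC2(CCC2)CC1)N1CC(c2nc(-c3cccc(Cl)c3)no2)C1` is measured in an assay on HEK293 cells for positive allosteric modulation of metabotropic glutamate receptor 5 (Homo sapiens), read by FLIPR (on this read-out lower numbers stand for an effect already at smaller amounts and higher numbers for an effect only at larger amounts of compound), and gives 1100 nM. Among the three compounds measured so far this is the second highest number. Compound 1 `O=C(C1CCC(F)(F)CC1)N1CC(c2nc(-c3cccc(Cl)c3)no2)C1` gives 180 nM in this assay, and compound 2 `O=C(c1ccc(F)c(F)c1)N1CC(c2nc(-c3cccc(F)c3)no2)C1` gives 3200 nM. The one step that joins two of these compounds by a single change is a 6.1-fold higher number from compound 1 to compound 3 (0.79 log units; beyond the scatter), where a larger all-carbon ring pair replaced a fluorinated six-membered ring on the carbonyl carbon and the number rose.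

Compound 4 `O=C(N1CCC(F)CC1)N1CC(c2nc(-c3cccc(Cl)c3)no2)C1` differs from compound 3 in that place: a group of 7 heavy atoms (5 carbon, 1 nitrogen, 1 fluorine; one six-membered non-aromatic ring with 1 hetero atom) in place of a group of 9 heavy atoms (9 carbon; one four-membered non-aromatic ring of carbon only, one six-membered non-aromatic ring of carbon only), on a carbonyl carbon. Going by the values given here, the change goes the other way from the step just described, back to a smaller fluorinated six-membered ring, though now with a nitrogen in the ring joined to the carbonyl carbon, which no measured pair covers directly. Given that compound 1 with its fluorinated ring gives 180 nM, a drop in number is expected, and the step is estimated at a 2.8-fold lower number from compound 3 to compound 4 (0.44 log units; beyond the scatter). Compound 4 is therefore expected to give about 400 nM in this assay, within a range of 120 nM to 1500 nM.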

Compound 4, half-maximal effective concentration: 990 nM
Compound 4: middle estimate off by 2.5-fold (0.39 log units), on the low side; low and high end bracket the measured number.
By their numbers in this assay, from the lowest: compound 1; then compounds 4 and 3 (each within the scatter of the next); then compound 2.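

In this assay the change on the carbonyl carbon to 4-fluoropiperidin-1-yl gives a 1.1-fold lower number from compound 3 to compound 4 (0.05 log units; within the scatter) and so shows that a smaller ring carrying fluorine is not enough to reach the low number of compound 1. Set against compound 1, the same group gives a 5.5-fold higher number from compound 1 to compound 4 (0.74 log units; beyond the scatter) and shows that 4,4-difluorocyclohexyl and 4-fluoropiperidin-1-yl are not interchangeable at this place, although both are six-membered rings carrying fluorine. Nothing available here explains these numbers.

The two groups differ both in the ring nitrogen and in their count of fluorine, so the compounds shown leave open which of these matters, a question that 4,4-difluoropiperidin-1-yl on the same carbonyl carbon would address. From the compounds shown here alone, how piperidin-1-yl without any fluorine would read also remains open.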